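Methyl for propanoyl on the aromatic nitrogen

This account rests on a few compounds, and the source may have more. Where it says the series, first, only, none or still open, it means among the compounds named here.

Measured compounds:
compound 1, `CCC(=O)n1nc(C)c(-c2ccc(Cl)c(Cl)c2)c1N`, in an assay on Sf9 cells for inhibition of mitogen-activated protein kinase kinase kinase 14 (Homo sapiens), read by ADP-Glo, with a stated time of 60 min; on this read-out lower numbers stand for stronger inhibition and higher numbers for weaker inhibition: 27400 nM
compound 2, `Cc1nn(C(=O)c2cccnc2)c(N)c1-c1ccc(Cl)c(Cl)c1`, in this assay: > 100000 nM, a limit of the assay rather than a number
compound 3, `Cc1nn(C)c(N)c1-c1ccc(Cl)c(Cl)c1`: not yet measured

Among the compounds with values here, compound 1 stands as the only number among the values shown. Compound 2 reaches only the limit (the limit of > 100000 nM in this assay, at which 1 of the 2 values shown sits). Within the data shown here, the single measured step, an at least 3.6-fold higher number from compound 1 to compound 2 (0.56 log units; beyond the scatter), alters the group on the carbonyl carbon, whereas compound 3 differs from compound 1 in another way: methyl in place of propanoyl on an aromatic nitrogen. Among the measured compounds shown here, the carbonyl that both measured compounds share is therefore removed, and no measured step covers that change, so the one step bears on it only loosely. Without a closer comparison, a step of no firm direction is expected, with a wide range. Compound 3 is estimated at 40000 nM in this assay, between 8000 nM and 200000 nM. For compound 3 this estimate means a 1.5-fold higher number from compound 1 to compound 3 (0.16 log units; within the scatter).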

Compound 3, half-maximal inhibitory concentration: > 100000 nM
Compound 3 gave a limit, no number; the forecaster's own chance of this, stated with the estimate: 35%; middle value at least 2.5-fold (0.39 log units) away from the limit.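

In this assay, replacing propanoyl with methyl on the aromatic nitrogen gives an at least 3.6-fold higher number from compound 1 to compound 3 (0.56 log units; beyond the scatter) as a lower bound on the change. Within the data shown here, the earlier step altered only the group on the carbonyl carbon, whereas this one shows that losing the whole propanoyl group also takes the read-out beyond the scatter from compound 1, which remains the only compound of the three with a number. Neither the full size of these steps nor any order between compound 2 and compound 3 can be read, because both stop at a limit rather than a number: the limit of > 100000 nM in this assay, at which 2 of the 3 values shown sit.

The compounds shown do not separate the carbonyl from the length of the chain on this nitrogen. A propyl chain without the carbonyl, or an acetyl or butanoyl group, would bear on that question.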